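The source may hold more compounds than are shown below. What is called first, only, known or untested is meant among the compounds shown, and "the series" means these compounds.

Of the compounds shown here, three that share one core have been measured in a functional assay on MCF7 cells (Homo sapiens) for cytotoxicity, read by sulforhodamine B assay, with a stated time of 48 h; a lower number here means a stronger inhibitor, a higher number a weaker inhibitor. Compound 1 `COc1ccc(C2C(C#N)=C(/N=C/c3ccc(F)cc3)Oc3nc(Nc4ccc(S(N)(=O)=O)cc4)sc32)cc1` gives 28900 nM in this assay. Compound 2 `COc1ccc(C2C(C#N)=C(/N=C/c3ccc(Cl)cc3Cl)Oc3nc(Nc4ccc(S(N)(=O)=O)cc4)sc32)cc1` gives 23500 nM. Compound 3 `COc1ccc(C2C(C#N)=C(/N=C/c3ccc([N+](=O)[O-])cc3)Oc3nc(Nc4ccc(S(N)(=O)=O)cc4)sc32)cc1` gives 9700 nM, the lowest number of the three: the nearest of the other two is compound 2, and the change a 2.4-fold lower number from compound 2 to compound 3 (0.38 log units; beyond the scatter); the furthest is compound 1, and the change a 3.0-fold lower number from compound 1 to compound 3 (0.47 log units; beyond the scatter). Both of these steps alter the group on the carbon with a double bond to nitrogen, so they bear directly on the next compound.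

Compound 4 `COc1ccc(C2C(C#N)=C(/N=C/C=C/c3ccccc3)Oc3nc(Nc4ccc(S(N)(=O)=O)cc4)sc32)cc1` has not yet been measured. It differs from compound 3 in one place: 2-phenylethenyl in place of 4-nitrophenyl on a carbon with a double bond to nitrogen. In the two measured steps, putting a nitro group on this ring went with a modestly lower number, whereas a fluorine or two chlorines gave numbers close to each other. Taking the nitro away again, and also replacing the ring with a longer group, is expected to move the number back up by about the same modest amount, though no measured step shows this exact group. The step this estimate implies, a 2.3-fold higher number from compound 3 to compound 4 (0.36 log units; beyond the scatter), is expected to lie just beyond the scatter. Compound 4 is therefore expected to give 22000 nM, within a range from 8000 nM to 60000 nM.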

Compound 4, half-maximal inhibitory concentration: 28900 nM
Compound 4: the middle estimate sits 1.3-fold (0.12 log units) below what was measured; the range from low to high includes it.
By their numbers in this assay, from the lowest: compound 3; then compounds 2, 1 and 4 (each within the scatter of the next).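

In this assay, swapping 4-nitrophenyl for 2-phenylethenyl on a carbon with a double bond to nitrogen gives a step beyond the scatter (a 3.0-fold higher number from compound 3 to compound 4 (0.47 log units; beyond the scatter)), whereas setting the same group against the two halogen-bearing rings gives steps within it (a 1.2-fold higher number from compound 2 to compound 4 (0.09 log units; within the scatter); no change at the digits printed from compound 1 to compound 4 (within the scatter)). The earlier compounds shown here had only substituted phenyl rings at this place, so compound 4 adds something new: a ring without substituents, carried on an ethenyl link, sits level with the fluorinated and chlorinated compounds. Among these four, compound 3 is thus the only one that stands apart, and no measurement shown here explains why.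

As far as these compounds go, it remains open whether the lower number follows the nitro group itself, which a ring bearing an amine, a nitrile or a carboxylic acid in its place would help to test. Also unresolved is whether a nitro group on the ring of the 2-phenylethenyl group would lower the number again, and whether a saturated 2-phenylethyl chain would match compound 4.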